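A smaller ring on the aryl amine of compound 2

The compounds below may be only part of what the source reports. "The series", "measured", "known", "first", "only" and "open" are said of these compounds alone.

Compound 2 `CCC(=O)Nc1cccc(Oc2nc(Nc3ccc(N4CCC(OC)CC4)cc3OC)ncc2Cl)c1` gives the lowest of the three numbers measured in an assay on isolated protein for inhibition of NUAK family SNF1-like kinase 1 (Homo sapiens), read by ADP-Glo, with a stated time of 60 min, tested at 10 uM, in the presence of a further agent that is not named here (on this read-out higher numbers stand for more inhibition at the one concentration tested (going by the name of the read-out) and lower numbers for less inhibition), namely 5.08%. Compound 1 `CCC(=O)Nc1cccc(Oc2nc(Nc3ccc(N(C)C)cc3OC)ncc2Cl)c1` gives 80.6% in this assay, and compound 3 `CCC(=O)Nc1cccc(Oc2nc(Nc3ccc(N4CCC(OC)CC4)cc3)ncc2Cl)c1` gives 86.5%. Both steps that touch compound 2 were large: a number 75.5 percentage points lower from compound 1 to compound 2 (beyond the scatter), and a number 81.4 percentage points higher from compound 2 to compound 3 (beyond the scatter). Compound 4 `CCC(=O)Nc1cccc(Oc2nc(Nc3ccc(N4CCCC4)cc3OC)ncc2Cl)c1` differs from compound 2 in one place: pyrrolidin-1-yl in place of 4-methoxypiperidin-1-yl on an aromatic carbon. Among the measured compounds shown here, the step that bears on this is the one from compound 1, because a number 75.5 percentage points lower from compound 1 to compound 2 (beyond the scatter) shows that the smaller dimethylamino group went with far more inhibition than 4-methoxypiperidin-1-yl. Pyrrolidin-1-yl lies between those two in size, so compound 4 is expected to recover part of that loss, with an estimated a number 49.9 percentage points higher from compound 2 to compound 4 (beyond the scatter) in this assay. The estimate for compound 4 is 55%, ranging from 15% to 90%.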

Compound 4, a percentage reported as inhibition, at one concentration (the size of the read-out at that concentration, not a potency): 25.8%
Beside the measured number, compound 4's estimate is 29.2 percentage points above it; measured number inside the range.
By their numbers in this assay, from the lowest: compound 2; then compound 4; then compounds 1 and 3 (each within the scatter of the next).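

In this assay the pyrrolidin-1-yl ring recovers only part of the inhibition at this position, with a number 20.7 percentage points higher from compound 2 to compound 4 (beyond the scatter) and still a number 54.8 percentage points lower from compound 1 to compound 4 (beyond the scatter). Among compounds 1, 2 and 4, which all keep the methoxy group, the number rises as the group shrinks, but the open-chain dimethylamino stands well apart from the smaller ring. Nothing available explains these differences.

From the compounds shown here alone, whether the ring oxygen of the 4-methoxypiperidin-1-yl group or its ring size matters more stays open, as a plain piperidine would be needed to separate them. Also open, going by these compounds, is whether compound 4 would gain from hydrogen in place of methoxy, as compound 2 did.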